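From amino to benzyl(methyl)amino on the shared core

The compounds below may be only part of what the source reports. "The series", "measured", "known", "first", "only" and "open" are said of these compounds alone.

Values from a functional assay on the whole organism for antagonist activity, with Mus musculus as the target (a lower number here means that less compound is needed, a higher number that more compound is needed for the effect), for the compounds in this account:

Compound 1 `CCC(=O)N(c1cccc(C)c1)C1CCCC1N(C)C` gives 1 mg/kg; 1 mg/kg (2 entries)
Compound 2 `CCC(=O)N(c1ccc(Cl)c(Cl)c1)C1CCCC1N` gives 0.8 mg/kg
Compound 3 `CCC(=O)N(c1ccc(Cl)c(Cl)c1)C1CCCC1N(C)Cc1ccccc1` has not yet been measured

For compound 2 the reading of 0.8 mg/kg is the only number shown, and one further entry gives no single number. Compound 3 carries benzyl(methyl)amino in place of amino on a saturated ring carbon. For the measured compounds named here, no measured pair isolates this change. In this assay the expected 6.3-fold higher number from compound 2 to compound 3 (0.80 log units; beyond the scatter) is a rise in dose beyond the scatter, though this estimate is uncertain. Compound 3 is expected at 5 mg/kg with an estimated range of 1 mg/kg to 30 mg/kg in that assay.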

Compound 3, dose for half-maximal effect: 40 mg/kg
Compound 3: middle estimate off by 8.0-fold (0.90 log units), on the low side; measured number above the stated range.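

In this assay, for the compounds shown here, benzyl(methyl)amino in place of amino on a saturated ring carbon gives a 50-fold higher number from compound 2 to compound 3 (1.70 log units; beyond the scatter) and is the first change at this position that can be read on its own. Compound 1 differs from compound 2 in more than one place and could not show this. For this pair, the larger group at this position comes with a much higher dose, and nothing at hand explains the rise. Methyl and benzyl enter together here, so the compounds shown leave open whether benzylamino or methylamino alone would give a step of similar size.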